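The compounds below may be only part of what the source reports. "The series", "measured", "known", "first", "only" and "open" are said of these compounds alone.

Compound 1, `Cc1ccc(-n2nc(C(=O)Nc3ccc(Oc4ncnc5ccsc45)cc3)c(C)cc2=O)cc1`, is the reference point of this small set. In a functional assay on A549 cells (Homo sapiens) for cytotoxicity, read by MTT assay, with a stated time of 72 h (on this read-out lower numbers stand for stronger inhibition and higher numbers for weaker inhibition), compound 1 gives 11500 nM. Compound 2, `Cc1ccc(-n2nc(C(=O)Nc3ccc(Oc4ncnc5ccsc45)c(F)c3)c(C)cc2=O)cc1`, carries a single change against compound 1: fluoro in place of hydrogen on an aromatic carbon. In this assay compound 2 gives 5890 nM, which corresponds to a 2.0-fold lower number from compound 1 to compound 2 (0.29 log units; within the scatter).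

Compound 3, `Cc1cc(=O)n(-c2ccccc2C(F)(F)F)nc1C(=O)Nc1ccc(Oc2ncnc3sccc23)cc1`, is built on another core; the difference between the core of compound 1 and that of compound 3 is not broken down here. In this assay compound 3 gives 19900 nM. Set against the two values of compound 1 and compound 2, this is the highest of the three numbers, but the gap to compound 1 lies within the usual scatter, while the gap to compound 2 lies beyond it.

Compound 4, `Cc1cc(=O)n(-c2ccccc2C(F)(F)F)nc1C(=O)Nc1ccc(Oc2ncnc3sccc23)c(F)c1`, has not yet been measured. It stands to compound 3 as compound 2 stands to compound 1: fluoro in place of hydrogen on an aromatic carbon. The surroundings of the place are described in the same words for both pairs, so this is the same change carried over to the core of compound 3. For the measured compounds named here, because the only observed instance of this change, a 2.0-fold lower number from compound 1 to compound 2 (0.29 log units; within the scatter), stayed within the scatter, a step of similar size is expected, namely a 2.0-fold lower number from compound 3 to compound 4 (0.30 log units; within the scatter). On that basis compound 4 is estimated to give 10000 nM in this assay, with a plausible range from 4000 nM to 25000 nM.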

Compound 4, half-maximal inhibitory concentration: 16300 nM
Estimate against measurement, compound 4: 1.6-fold (0.21 log units) below; the range from low to high includes it.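

Carried over to the second core, fluoro in place of hydrogen on an aromatic carbon gives, in this assay, a 1.2-fold lower number from compound 3 to compound 4 (0.09 log units; within the scatter). Set beside the earlier step, the new one shows no difference between the two cores: the same change on two cores in this assay, a 2.0-fold lower number (0.29 log units; within the scatter) from compound 1 to compound 2 and a 1.2-fold lower number (0.09 log units; within the scatter) from compound 3 to compound 4, 1.6-fold (0.20 log units) apart, within the scatter of two such steps. This shows that, within what this assay can resolve, the change read the same way on these two cores, so carrying the earlier step over was reasonable here, but it does not show that fluoro moves the number on either core, since each step by itself stays within the scatter, and two pairs cannot speak for the whole series.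

The compounds shown leave open whether another group on that same aromatic carbon, such as chloro, methoxy or a nitrile, would give a step that clears the scatter. As far as these compounds go, they also leave open whether the change would read the same on a core where an amine, a carboxylic acid or a longer chain stands in place of the trifluoromethyl or the methyl, so any wider rule for this change remains untested by these four compounds.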